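From 4-chlorophenyl to 4-methylphenyl on the shared core

The compounds below may be only part of what the source reports. "The series", "measured", "known", "first", "only" and "open" are said of these compounds alone.

Three compounds are in view: compound 1 `COc1cc(C(=O)c2sc3ccccc3c2-c2ccccc2)cc(OC)c1OC`, compound 2 `COc1cc(C(=O)c2sc3ccccc3c2-c2ccc(Cl)cc2)cc(OC)c1OC` and compound 3 `COc1cc(C(=O)c2sc3ccccc3c2-c2ccc(C)cc2)cc(OC)c1OC`. In a functional assay on A549 cells (Homo sapiens) for antiproliferative activity, read by MTT assay, with a stated time of 72 h (on this read-out lower numbers stand for stronger inhibition and higher numbers for weaker inhibition), compound 1 gives 5000 nM. In the same read-out compound 2 gives 7500 nM. These two numbers lie within the scatter of each other, so compound 2 has no separate standing in this pair.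

The change under review is methyl in place of chloro on an aromatic carbon, para to a large group. For the measured compounds named here, only one measured step bears on it. That step is a 1.5-fold higher number from compound 1 to compound 2 (0.18 log units; within the scatter), chloro in place of hydrogen on the same aromatic carbon, and it stays within the scatter. Going by the values given here, no compound carrying methyl at this place has been measured yet, so the evidence is thin and gives no direction. No step beyond the scatter is expected in this assay. The estimate amounts to a 1.3-fold lower number from compound 2 to compound 3 (0.10 log units; within the scatter), which is expected to remain within the scatter. Compound 3 is estimated at 6000 nM, with an expected range from 2500 nM to 14000 nM.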

Compound 3, half-maximal inhibitory concentration: 7800 nM
For compound 3 the middle estimate is 1.3-fold (0.11 log units) below the measured one; the range from low to high includes it.
By their numbers in this assay, from the lowest: compounds 1, 2 and 3 (each within the scatter of the next).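

In this assay, methyl now joins hydrogen and chloro at this carbon, and methyl in place of chloro gives a 1.0-fold higher number from compound 2 to compound 3 (0.02 log units; within the scatter) on the shared core. Methyl in place of hydrogen gives a 1.6-fold higher number from compound 1 to compound 3 (0.19 log units; within the scatter) and so, like chloro in place of hydrogen, does not move the number beyond the scatter; across compounds 1, 2 and 3, all three pairs now lie within the scatter of each other at this aromatic carbon, para to a large group, and none of the three goes against this. No supporting evidence is available to account for this result.

With only hydrogen, chloro and methyl at this carbon, the compounds shown leave open whether an amine, a carboxylic acid or a longer chain there would give a step beyond the scatter in this assay on this core. Also open, as far as these compounds go, is whether methyl in place of chloro on another carbon of the same ring would read the same way.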